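A hydroxy in place of cyano: what to expect for compound 3

The compounds below may be only part of what the source reports. "The series", "measured", "known", "first", "only" and "open" are said of these compounds alone.

Compound 1 `CN(C)C(=O)c1cccnc1NCCCN1CCN(c2ccccc2)CC1` and compound 2 `CN(C)C(=O)c1cccnc1NCCCN1CCN(c2ccccc2C#N)CC1` share one core; compound 2 bears a cyano group where compound 1 has none. In a functional assay on aorta for antagonist activity at Alpha-1D adrenergic receptor (Rattus norvegicus) (on this read-out higher numbers stand for weaker binding and lower numbers for tighter binding), compound 1 gives 15.9 nM and compound 2 gives 10 nM; the step of a 1.6-fold lower number from compound 1 to compound 2 (0.20 log units; within the scatter). Among the measured compounds shown here, of the two numbers known so far, compound 2 has the lower one, but its distance from compound 1 is within the scatter, so no order between them can be read.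

Compound 3 `CN(C)C(=O)c1cccnc1NCCCN1CCN(c2ccccc2O)CC1` has not yet been measured in this assay. It differs from compound 2 in one place: hydroxy in place of cyano on an aromatic carbon. For the measured compounds named here, only one measured step touches this carbon, the one from compound 1 to compound 2, and it stayed within the scatter. Going by the values given here, no measured step covers an exchange of cyano for hydroxy, so the only guide is that the one change seen at this position moved the number little. Compound 3 is therefore expected to remain close to compound 2, a 1.6-fold higher number from compound 2 to compound 3 (0.20 log units; within the scatter). Compound 3 is estimated at 16 nM, with a range from 5 nM to 50 nM.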

Compound 3, dissociation constant: 63.1 nM
Compound 3: middle estimate off by 3.9-fold (0.60 log units), on the low side, outside the stated range (above it).
By their numbers in this assay, from the lowest: compounds 2 and 1 (each within the scatter of the next); then compound 3.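

In this assay this position, on an aromatic carbon ortho to a large group, proves sensitive to the group it carries, since hydroxy in place of cyano gives a 6.3-fold higher number from compound 2 to compound 3 (0.80 log units; beyond the scatter). Hydroxy in place of hydrogen at the same carbon also gives a step beyond the scatter, a 4.0-fold higher number from compound 1 to compound 3 (0.60 log units; beyond the scatter), so compound 3 stands apart from both earlier compounds and its weaker binding cannot be read simply as the loss of the cyano group. Among these three compounds, the hydrogen and cyano analogues cannot be ordered, while the hydroxy analogue has the highest number; nothing available explains why this exchange matters here.

What the compounds shown leave open is whether an amine, a methoxy group or a carboxylic acid on this carbon would give a number near those of compound 1 and compound 2, near that of compound 3, or higher still. They also leave open whether hydroxy would give a step of similar size on another carbon of the same aromatic ring, or with a longer chain in the shared core.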